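The compounds below may be only part of what the source reports. "The series", "measured", "known", "first", "only" and "open" are said of these compounds alone.

Of the compounds shown here, three built on a shared core have been measured in a functional assay on HeLa cells (Homo sapiens) for inhibition; a lower number here means a stronger inhibitor, a higher number a weaker inhibitor. Compound 1 `CC(=O)OC(C)n1cnc2c(Cl)nc(N)nc21` carries a chloro group on its core. In this assay compound 1 gives > 500000 nM, which is a limit of the assay and not a number. Compound 2 `CC(=O)OCCOn1cnc2c(Cl)nc(N)nc21` likewise gives a limit in this assay, > 500000 nM. The difference between the core of compound 1 and the core of compound 2 is not broken down here. Compound 3 `CC(=O)OC(C)n1cnc2c(S)nc(N)nc21` differs from compound 1 by sulfanyl in place of chloro on an aromatic carbon. In this assay compound 3 gives 89000 nM. The step of an at least 5.6-fold lower number from compound 1 to compound 3 (0.74 log units; beyond the scatter) can be stated only as a bound because of the limit of > 500000 nM in this assay, at which 2 of the 3 values shown sit. For the measured compounds named here, compound 4 `CC(=O)OCCOn1cnc2c(S)nc(N)nc21` has not yet been measured; it differs from compound 2 by sulfanyl in place of chloro on an aromatic carbon, which is the same change, at the same place, as the one from compound 1 to compound 3. Resting on the step of an at least 5.6-fold lower number from compound 1 to compound 3 (0.74 log units; beyond the scatter), the change is expected to amount to an at least 3.3-fold lower number from compound 2 to compound 4 (0.52 log units; beyond the scatter). For compound 4 the value in this assay is estimated at 150000 nM, between 50000 nM and 500000 nM.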

Compound 4, half-maximal inhibitory concentration: 5000 nM
Compound 4: middle estimate off by 30-fold (1.48 log units), on the high side; the measured number lies below the stated range.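

In this assay, the second core responds in the same direction as the first, since sulfanyl in place of chloro on an aromatic carbon gives an at least 100-fold lower number from compound 2 to compound 4 (2.00 log units; beyond the scatter). The change therefore lowers the number on both cores shown, and no compound here goes against that, so its direction carries from one core to the other: the same change on two cores in this assay, an at least 5.6-fold lower number (0.74 log units; beyond the scatter) from compound 1 to compound 3 and an at least 100-fold lower number (2.00 log units; beyond the scatter) from compound 2 to compound 4; the limit leaves it open whether they differ This does not show that the size of the change carries over, and two cores are too few to promise the same result on a third, because each step starts from a limit and can be stated only as a bound: the limit of > 500000 nM in this assay, at which 2 of the 4 values shown sit.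

The compounds shown leave open whether sulfanyl is special at this aromatic carbon or whether another group there, such as an amine, a hydroxyl or a longer chain joined through sulfur, would also lower the number. They also leave open how the swap would behave on a core with a different chain in place of those on compound 1 and compound 2, for example a carboxylic acid.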